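The source may report more compounds than this note shows. Statements on the series, on what has been measured and on what is new or still open speak of the compounds shown alone.

Measured in a functional assay on A549 cells (Homo sapiens) for antiproliferative activity, read by MTT assay, with a stated time of 48 h; a higher number here means a weaker inhibitor, a lower number a stronger inhibitor:
- Compound 1 `COc1ccc(-c2cncc3[nH]c(=O)n(Cc4cc(OC)c(OC)c(OC)c4)c23)cc1`: > 20000 nM
- Compound 2 `COc1ccc(-c2cc3c(cn2)[nH]c(=O)n3-c2cc(OC)c(OC)c(OC)c2)cc1`: 1120 nM
- Compound 3 `COc1ccc(-c2cc3c(cn2)[nH]c(=O)n3-c2cc(OC)c(OC)c(OC)c2)cc1F`: 2020 nM

In this assay, compound 1 has only a limit, > 20000 nM, and not a number. Compound 1 also differs from compound 2 in more than one place, so it provides no single-change comparison here.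

That leaves two actual numbers in this small set. Compound 2 gives 1120 nM and compound 3 gives 2020 nM, and these two values lie within the scatter of each other.

The next compound to be tested is compound 4 `COc1ccc(-c2cc3c(cn2)[nH]c(=O)n3-c2cc(OC)c(OC)c(OC)c2)cn1`. It has 6-methoxypyridin-3-yl in place of the 4-methoxyphenyl of compound 2, on an aromatic carbon of the shared core: 6-methoxypyridin-3-yl in place of 4-methoxyphenyl on an aromatic carbon.

Going by the values given here, only one measured step bears on this change. It also alters this aryl group. That step, a fluoro in place of hydrogen on an aromatic carbon, is a 1.8-fold higher number from compound 2 to compound 3 (0.26 log units; within the scatter). It is a different edit from swapping a ring carbon for nitrogen, so it offers only a rough guide. On this evidence, only a small rise in the number is expected in this assay, possibly no change beyond the scatter.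

The expected change is a 1.4-fold higher number from compound 2 to compound 4 (0.15 log units; within the scatter).

For compound 4 the estimated value is 1600 nM, with an expected range of 600 nM to 5000 nM.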

Compound 4, half-maximal inhibitory concentration: 1220 nM
Beside the measured number, compound 4's estimate is 1.3-fold (0.12 log units) above it; the measured number falls inside the stated range.
By their numbers in this assay, from the lowest: compounds 2, 4 and 3 (each within the scatter of the next). At a limit, above all of these: compound 1.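

In this assay, 6-methoxypyridin-3-yl in place of 4-methoxyphenyl gives a 1.1-fold higher number from compound 2 to compound 4 (0.04 log units; within the scatter), so this aromatic carbon of the shared core, next to the ring nitrogen, can carry an aryl ring with a hetero atom and stay within the scatter of the all-carbon ring. The comparison with the fluorinated aryl group points the same way: 6-methoxypyridin-3-yl in place of 3-fluoro-4-methoxyphenyl gives a 1.7-fold lower number from compound 3 to compound 4 (0.22 log units; within the scatter), which means that the three aryl groups now tested here all lie within the scatter of one another, and the additional hydrogen-bond acceptor counted in the entering group shifts the number by no more than that scatter. Nothing measured in this set speaks to why these values lie so close together.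

As far as these compounds go, all three aryl groups still carry a methoxy group, so what an amine or a carboxylic acid would do in its place remains open. Also open, from the compounds shown here alone, is whether a saturated ring such as piperidine could replace the aryl ring at this carbon, or whether an aromatic ring is needed there.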